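The source may report more compounds than this note shows. Statements on the series, on what has been measured and on what is new or still open speak of the compounds shown alone.

Of the compounds shown here, two have been measured in an assay (Equus caballus) for inhibition of Thromboxane-A synthase (Homo sapiens), using microsomes; on this read-out lower numbers stand for stronger inhibition and higher numbers for weaker inhibition. Compound 1, `CSC(CCC/C=C(\c1ccccc1)c1cccnc1)C(=O)O`, gives 30 nM in this assay. Compound 2, `O=C(O)CCCC/C=C(\c1cccnc1)c1cccc(Br)c1`, gives 180 nM, a higher number that lies beyond the scatter, so compound 1 stands as the lower of the two numbers here. Compound 3, `CC(C)(CCC/C=C(\c1ccccc1)c1cccnc1)C(=O)O`, has not yet been measured in this assay. It differs from compound 1 in one place: 1-carboxy-1-methylethyl in place of carboxy(methylsulfanyl)methyl on a saturated chain carbon, three bonds along the chain from a double-bonded chain carbon. In other words, the sulfur-bearing group is swapped for a second methyl group on the same chain carbon while the carboxylic acid stays. Among the compounds with values here, no measured pair shows this kind of exchange, so its effect is open. The expected step from compound 1 to compound 3 is a 1.5-fold higher number from compound 1 to compound 3 (0.18 log units; within the scatter), a change that is expected to stay within the scatter. Compound 3 is therefore estimated to give about 45 nM in this assay, with a range from 12 nM to 180 nM.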

Compound 3, half-maximal inhibitory concentration: 21 nM
Compound 3: the middle estimate sits 2.1-fold (0.33 log units) above what was measured; low and high end bracket the measured number.
By their numbers in this assay, from the lowest: compounds 3 and 1 (each within the scatter of the next); then compound 2.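

In this assay the exchange of carboxy(methylsulfanyl)methyl for 1-carboxy-1-methylethyl gives a 1.4-fold lower number from compound 1 to compound 3 (0.15 log units; within the scatter) and so leaves the two compounds indistinguishable on this read-out. At this place, on a saturated chain carbon, three bonds along the chain from a double-bonded chain carbon, the sulfur of the leaving group is therefore not required for a number of this size, since a group containing only carbon and oxygen matches it. No other measurement accompanies this result, so it offers no explanation for the match.

As far as these compounds go, whether a larger group, such as a cyclohexyl ring or two ethyl groups, would be accepted on this chain carbon remains open. So does the outcome of replacing the carboxylic acid, present in every compound shown, with an amide or a tetrazole.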